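Thiophene urea series: swapping the ester tail for cyclobutyl

A few compounds are considered here, and "the series" means these few. Any claim that something is new, unique, unknown or untested is made for them only; others in the source may bear on it.

Compound 1 `CC(C)(C)OC(=O)CCCN1CCc2c(sc(NC(=O)Nc3ccc(Cl)cc3)c2C(N)=O)C1` gives 560 nM in a functional assay (strain AB) with Danio rerio as the target, read by microscopy, with a stated time of 1 h (a lower number here means that less compound is needed, a higher number that more compound is needed for the effect), the lowest of the two numbers recorded. Compound 3 `CC1(C)Cc2c(sc(NC(=O)Nc3ccc(Cl)cc3)c2C(N)=O)C(C)(C)N1` gives 1240 nM in this assay, a higher number that lies beyond the scatter. Compound 2 `CCN1CCc2c(sc(NC(=O)[C@@H]3CCCN3)c2C(N)=O)C1` reaches only a limit of the assay, > 25000 nM, in this assay; this is the limit of > 25000 nM in this assay, at which 1 of the 3 values shown sits.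

Compound 4 `NC(=O)c1c(NC(=O)Nc2ccc(Cl)cc2)sc2c1CCN(CC1CCC1)C2` carries the shared core of compound 1 with one change: cyclobutyl in place of 2-(tert-butoxycarbonyl)ethyl on a saturated chain carbon bound to an amine nitrogen in a ring. Going by the values given here, no measured pair shows this exact change, so the size of the step is open. In this assay the step from compound 1 to compound 4 is expected to be small, a 1.2-fold lower number from compound 1 to compound 4 (0.09 log units; within the scatter), with no direction assured beyond the scatter. Compound 4 is therefore estimated at 450 nM, between 150 nM and 1500 nM.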

Compound 4, half-maximal effective concentration: 1360 nM
The estimate for compound 4 lay 3.0-fold (0.48 log units) below the measured number, and the stated range covers the measured number.
By their numbers in this assay, from the lowest: compound 1; then compounds 3 and 4 (each within the scatter of the next). At a limit, above all of these: compound 2.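

Cyclobutyl in place of 2-(tert-butoxycarbonyl)ethyl on a saturated chain carbon bound to an amine nitrogen in a ring gives a 2.4-fold higher number from compound 1 to compound 4 (0.39 log units; beyond the scatter) as the first step read at this place. The entering group has no hydrogen-bond acceptors, yet compound 4 still gives 1360 nM in this assay, so the ester is not required for a measurable effect.

A carboxylic acid or a longer chain at this place could help separate the roles of the ester, the chain size and the ring. No measured property at hand bears on this step.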